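This account rests on a few compounds, and the source may have more. Where it says the series, first, only, none or still open, it means among the compounds named here.

Measured compounds and values:

- compound 1 `COC(=O)N(C)CC#CCN1CCCC1` — in a functional assay on the whole organism for antagonist activity, with Mus musculus as the target (on this read-out lower numbers stand for an effect already at smaller amounts and higher numbers for an effect only at larger amounts of compound), compound 1 gives > 10 mg/kg, which is a limit of the assay and not a number.
- compound 2 `COC(=O)N(C)CC#CCn1ccnc1` — in this assay compound 2 gives > 100 mg/kg, again a limit of the assay.
- compound 3 `COC(=O)N(C)C(C)C#CCn1ccnc1` — in this assay compound 3 gives > 100 mg/kg, also a limit of the assay.

The cores of compound 1 and compound 2 differ by pyrrolidin-1-yl in place of 1H-imidazol-1-yl on a saturated chain carbon bound to a triple-bonded carbon. Across that change the step is a step that the two limits leave unreadable from compound 1 to compound 2. The change from compound 2 to compound 3 is methyl in place of hydrogen on a saturated chain carbon bound to an amide-type nitrogen and a triple-bonded carbon, and its step is a step that the two limits leave unreadable from compound 2 to compound 3; both of these compounds sit at the limit of > 100 mg/kg in this assay, at which 2 of the 3 values shown sit.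

Compound 4 `CCOC(=O)N(C)CC#CCN1CCCC1` has not yet been measured. It differs from compound 1 by methyl in place of hydrogen on a saturated chain carbon bound to an oxygen next to a carbonyl group. This is the same kind of change as that from compound 2 to compound 3, but not the same: in compound 3 the methyl enters on a saturated chain carbon bound to an amide-type nitrogen and a triple-bonded carbon, whereas in compound 4 it enters on a saturated chain carbon bound to an oxygen next to a carbonyl group, and the cores differ as told above.

For compound 4 in this assay the expected step is a step that the limit leaves unreadable from compound 1 to compound 4, an expectation that rests on the limit of > 10 mg/kg in this assay, at which 1 of the 3 values shown sits, for compound 1 and on the unreadable step that the two limits leave unreadable from compound 2 to compound 3, which gives no sign of a large shift from a single added methyl. The estimate for compound 4 is 30 mg/kg, expected to lie between 10 mg/kg and 300 mg/kg, and it is likely that the assay will once more report only a limit.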

Compound 4, dose for half-maximal effect: > 100 mg/kg
Compound 4: only a limit was reported; the forecaster's own chance of this, stated with the estimate: 75%; middle value at least 3.3-fold (0.52 log units) away from the limit.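

In this assay compound 4 gives > 100 mg/kg, which is a limit of the assay and not a number. Compound 1 likewise gives only a limit, > 10 mg/kg, so no step can be read between compound 1 and compound 4. The compounds shown leave open whether methoxycarbonyl to ethoxycarbonyl changes the read-out at all, and in which direction, since every value here is a limit.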